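Cyclohexylamino Acid Analogue Expected Near the Most Potent Compounds

The source may report more compounds than this note shows. Statements on the series, on what has been measured and on what is new or still open speak of the compounds shown alone.

Compound 1 `CCNC(=O)[C@H]1OC(n2cnc3c(NC4CCCCC4)ncnc32)[C@H](O)[C@@H]1O`: 1.7 nM
Compound 2 `CNc1ncnc2c1ncn2C1O[C@H](C(=O)O)[C@@H](O)[C@H]1O`: 68 nM
Compound 3 `COc1ccc(Nc2ncnc3c2ncn3C2O[C@H](C(=O)O)[C@@H](O)[C@H]2O)cc1`: 1 nM

In an assay with adenosine receptor A1 (Rattus norvegicus) as the target (a lower number here means a stronger inhibitor, a higher number a weaker inhibitor), compound 3 gives the lowest number of the three measured compounds; compound 1 lies close to it, while compound 2 sits far higher. Going by the values given here, the single measured step that bears on the amine substituent, a 68-fold lower number from compound 2 to compound 3 (1.83 log units; beyond the scatter), was large. Compound 4 `O=C(O)[C@H]1OC(n2cnc3c(NC4CCCCC4)ncnc32)[C@H](O)[C@@H]1O` carries cyclohexyl in place of 4-methoxyphenyl on a nitrogen on an aromatic ring. Compound 1 shares this cyclohexylamino group and gives a number near that of compound 3, so the change in compound 4 is expected to cost little, with a 2.5-fold higher number from compound 3 to compound 4 (0.40 log units; beyond the scatter) estimated as the most likely outcome. Compound 4 is therefore expected to give about 2.5 nM in this assay, within a range of 0.8 nM to 10 nM.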

Compound 4, half-maximal inhibitory concentration: 0.86 nM
Beside the measured number, compound 4's estimate is 2.9-fold (0.46 log units) above it; measured number inside the range.
By their numbers in this assay, from the lowest: compounds 4, 3 and 1 (each within the scatter of the next); then compound 2.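

In this assay the group on the nitrogen takes a saturated ring as readily as an aromatic one: a 1.2-fold lower number from compound 3 to compound 4 (0.07 log units; within the scatter) stays within the scatter. With a 79-fold lower number from compound 2 to compound 4 (1.90 log units; beyond the scatter) beyond the scatter, cyclohexyl joins 4-methoxyphenyl in standing well apart from methyl. On the carbonyl carbon, a 2.0-fold lower number from compound 1 to compound 4 (0.30 log units; within the scatter) is also within the scatter, so hydroxy and ethylamino cannot be told apart when the cyclohexylamino group is present. The compounds shown leave open whether a smaller ring such as cyclopentyl or an unsubstituted phenyl would do the same, and whether a methyl ester would match the carboxylic acid. Nothing available gives a reason for these results.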